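From Methoxy to Chloro Without a Measured Baseline

The source may hold more compounds than are shown below. What is called first, only, known or untested is meant among the compounds shown, and "the series" means these compounds.

In a functional assay on B16-F10 cells (Mus musculus) for inhibition, read by MTT assay, with a stated time of 72 h (a lower number here means a stronger inhibitor, a higher number a weaker inhibitor), compound 1 `COc1ccccc1NC(=S)NC1CC(C)(C)Oc2ccc(Br)cc21` gives "not determined" (no result reported), so it offers no number as a starting point. Among the compounds with values here, compound 2 `CC1(C)CC(NC(=S)Nc2cccc([N+](=O)[O-])c2)c2cc(F)ccc2O1` gives 6000 nM, the only measured value here. Compound 3 `CC1(C)CC(NC(=S)Nc2ccccc2Cl)c2cc(Br)ccc2O1` keeps the core of compound 1 and changes one group: chloro in place of methoxy on an aromatic carbon, ortho to a large group. Within the data shown here, no measured step guides this change, so the expectation in this assay rests on the level of compound 2 at 6000 nM. Compound 3 is estimated at 5000 nM, with an expected range of 1500 nM to 20000 nM.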

Compound 3, half-maximal inhibitory concentration: 17000 nM
Beside the measured number, compound 3's estimate is 3.4-fold (0.53 log units) below it; low and high end bracket the measured number.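

Within the data shown here, with compound 1 at "not determined" (no result reported) in this assay no step to compound 3 can be read. From the compounds shown here alone, what chloro in place of methoxy does to inhibition stays open. No evidence bearing on this result is available.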